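A few compounds are considered here, and "the series" means these few. Any claim that something is new, unique, unknown or untested is made for them only; others in the source may bear on it.

Compound 1 `COc1ccc(-c2coc3cc(O)ccc3c2=O)c(O)c1` is one of two compounds tested in a functional assay on HeLa cells (Homo sapiens) for cytotoxicity, read by MTT assay, with a stated time of 72 h; a lower number here means a stronger inhibitor, a higher number a weaker inhibitor. For the measured compounds named here, there compound 1 gives 69800 nM, the only plain number in the set. Compound 2 `COc1ccc(-c2coc3cc(O)cc(O)c3c2=O)cc1O` reaches only a limit of the assay, > 100000 nM, and its result is a limit rather than a number (the limit of > 100000 nM in this assay, at which 1 of the 2 values shown sits). Compound 3 `COc1ccc(-c2coc3cc(O)cc(O)c3c2=O)c(O)c1` differs from compound 1 by hydroxy in place of hydrogen on an aromatic carbon. Going by the values given here, with no measured step of this kind to lean on, the expected change from compound 1 is small, within the usual scatter or slightly weaker, a 1.3-fold higher number from compound 1 to compound 3 (0.11 log units; within the scatter). Compound 3 is therefore estimated at 90000 nM, between 40000 nM and 200000 nM.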

Compound 3, half-maximal inhibitory concentration: > 100000 nM
Compound 3 gave a limit, no number (the forecaster's own chance of this, stated with the estimate: 50%); middle value at least 1.1-fold (0.04 log units) from the limit.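

In this assay, hydroxy in place of hydrogen on this aromatic carbon gives an at least 1.4-fold higher number from compound 1 to compound 3 (0.15 log units; that floor lies within the scatter). So this change brings no gain in strength at this position, but the true size of the step stays unknown, since the result for compound 3 is a limit and not a number. The compounds now gather at that ceiling: the limit of > 100000 nM in this assay, at which 2 of the 3 values shown sit.

On these data alone, what an amine or a chlorine atom on this same carbon would give remains open. So does how far past the limit compound 3 really lies.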